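This account rests on a few compounds, and the source may have more. Where it says the series, first, only, none or still open, it means among the compounds named here.

Of the compounds shown here, three on a shared core have been tested in a functional assay on SV5A8 cells (Homo sapiens) for cytotoxicity (on this read-out lower numbers stand for stronger inhibition and higher numbers for weaker inhibition), and every one of them returned only a limit rather than a number. Compound 1 `Cc1ccc2c(NCc3ccc(NC(=O)C4CCN(Cc5ccccc5)CC4)cc3)nc(N3CCCCCC3)nc2c1` gives in this assay a limit, > 6880 nM. Compound 3 `Cc1ccc2c(NCc3ccc(NC(=O)C4CCN(Cc5ccccc5)CC4)cc3)nc(N(C)CCN(C)C)nc2c1` gives in this assay a limit, > 8830 nM. Going by the values given here, the one step between measured compounds, a step that the two limits leave unreadable from compound 1 to compound 3, is therefore unreadable because both of its ends rest at limits the limit of > 6880 nM in this assay, at which 1 of the 3 values shown sits (the limit of > 8830 nM in this assay, at which 1 of the 3 values shown sits). Compound 2 `Cc1ccc2c(NCc3ccc(NC(=O)C4CCN(Cc5cc(Cl)ccn5)CC4)cc3)nc(N(C)C)nc2c1` gives in this assay a limit, > 5400 nM. Compound 2 thus stands at a limit (the limit of > 5400 nM in this assay, at which 1 of the 3 values shown sits), as do its two companions, and no ordering among the three can be drawn.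

Compound 4 `Cc1ccc2c(NCc3ccc(NC(=O)C4CCN(Cc5ccco5)CC4)cc3)nc(N(C)C)nc2c1` differs from compound 2 in a single place: furan-2-yl in place of 4-chloropyridin-2-yl on a saturated chain carbon bound to an amine nitrogen in a ring. Among the compounds with values here, no measured step touches this part of the molecule, and the only step available is unreadable, so there is nothing in the data to size the change. With all three measured compounds at limits, the expectation is that compound 4 also falls at or past the limit of this assay. Compound 4 is therefore estimated at 8000 nM, with a range from 3000 nM to 30000 nM. The step that the limit leaves unreadable from compound 2 to compound 4 is expected to be none beyond the scatter.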

Compound 4, half-maximal inhibitory concentration: > 20000 nM
Compound 4: no number, only a limit; the forecaster's own chance of this, stated with the estimate: 85%; middle value at least 2.5-fold (0.39 log units) from the limit.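

Compound 2 and compound 4 both returned only a limit in this assay, so the step between them, furan-2-yl in place of 4-chloropyridin-2-yl, cannot be read. The compounds shown leave open what number any of the four would reach in this assay, and whether any change on the shared core moves the read-out at all.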